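The source may report more compounds than this note shows. Statements on the series, on what has been measured and on what is new or still open speak of the compounds shown alone.

Going by the values given here, compound 1 `Fc1cc(Cl)ccc1-c1ccc(Cn2nnc3ccccc32)cn1` is the first of three measured compounds. In an ADME assay on microsomes from liver (Homo sapiens) for metabolic stability, tested at 2.5 uM (on this read-out lower numbers stand for slow clearance and higher numbers for fast clearance), compound 1 gives 0.01 mL/min/g. Compound 2 `Fc1cc(Cl)ccc1-c1ccc(Cn2nnc3c(C(F)(F)F)cccc32)cn1` carries one change against compound 1: trifluoromethyl in place of hydrogen on an aromatic carbon. That change made a 4.0-fold higher number from compound 1 to compound 2 (0.60 log units; beyond the scatter).

Compound 3 `Brc1cccc2c1nnn2CC1CC1` is built on a different core, and the difference between the two cores is not broken down here. In this assay compound 3 gives 1.3 mL/min/g, the highest of the three numbers, and compound 2 gives 0.04 mL/min/g.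

Compound 4 `FC(F)(F)c1cc(Br)c2nnn(CC3CC3)c2c1` stands to compound 3 as compound 2 stands to compound 1: trifluoromethyl in place of hydrogen on an aromatic carbon. It is the same kind of change, not the same one, since the place differs: in compound 2 the entering group sits ortho to a fused ring and meta to a fused ring, while in compound 4 it sits meta to a bromo group, meta to a fused ring and para to a fused ring.

Resting on the step that the change made from compound 1 to compound 2, one would expect a 2.0-fold higher number from compound 3 to compound 4 (0.30 log units; within the scatter) for compound 4, though the place differs and compound 3 already gives a high number. Compound 4 is therefore estimated at 2.6 mL/min/g, with a range from 0.9 mL/min/g to 7.5 mL/min/g.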

Compound 4, intrinsic clearance in a liver preparation (reported as CLH), per the amount of preparation that the assay uses: 0.1 mL/min/g
For compound 4 the middle estimate is 26-fold (1.41 log units) above the measured one; measured number outside the range, below it.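

In this assay, trifluoromethyl in place of hydrogen on an aromatic carbon gave a 13-fold lower number from compound 3 to compound 4 (1.11 log units; beyond the scatter), whereas the same kind of change on the other core gave a 4.0-fold higher number from compound 1 to compound 2 (0.60 log units; beyond the scatter). The two steps run in opposite directions and do not agree: the same change on two cores in this assay, a 4.0-fold higher number (0.60 log units; beyond the scatter) from compound 1 to compound 2 and a 13-fold lower number (1.11 log units; beyond the scatter) from compound 3 to compound 4, 52-fold (1.72 log units) apart, beyond the scatter of two such steps. This shows that neither the direction nor the size of the step carried from one core to the other in this series, but it does not show whether the core or the place of the entering group accounts for the disagreement, as both differ between the two pairs.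

The compounds shown leave open what trifluoromethyl would do on the core of compound 3 if it stood at the same place as in compound 2, and what it would do at the place it holds in compound 4 on the core of compound 1. They also leave open whether a nitrile or an amine on the same aromatic carbon would follow either step.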